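Chloro removal on two related cores: working notes

A few compounds are considered here, and "the series" means these few. Any claim that something is new, unique, unknown or untested is made for them only; others in the source may bear on it.

Compound 2 `O=c1c(Cl)c(CSC(=S)N2CCCCC2)oc2ccccc12` gives 1000 nM in a functional assay on MCF7 cells (Homo sapiens) for antiproliferative activity, read by MTT assay, with a stated time of 72 h; a lower number here means a stronger inhibitor, a higher number a weaker inhibitor. Compound 1 `O=c1cc(CSC(=S)N2CCCCC2)oc2ccccc12` gives > 25000 nM in this assay, a limit of the assay and not a number. The step of an at least 25-fold higher number from compound 2 to compound 1 (1.39 log units; beyond the scatter) follows the change (hydrogen in place of chloro on an aromatic carbon). Compound 3 `CC(C)N(C(=S)SCc1cc(=O)c2ccc(Cl)cc2o1)C(C)C` gives > 25000 nM in this assay, again a limit rather than a number. Compound 4 `CC(C)N(C(=S)SCc1cc(=O)c2ccccc2o1)C(C)C` stands to compound 3 through (hydrogen in place of chloro on an aromatic carbon); the difference between the two cores is not broken down here. The surroundings differ: in compound 2 the chloro sits on a six-membered aromatic ring with 1 oxygen, ortho to a group of 1 heavy atom, ortho to a large group, two atoms from the ring oxygen, whereas in compound 3 it sits on a six-membered aromatic ring of carbon only, so this is the same kind of change, not the same one. Since compound 3 already sits at the limit of > 25000 nM in this assay, at which 2 of the 3 values shown sit, and an at least 25-fold higher number from compound 2 to compound 1 (1.39 log units; beyond the scatter) weakened inhibition, no recovery is expected. Compound 4 is expected to remain at that limit, a step that the limit leaves unreadable from compound 3 to compound 4 beside the earlier one. The estimate for compound 4 in this assay is 45000 nM, between 25000 nM and 120000 nM.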

Compound 4, half-maximal inhibitory concentration: 31700 nM
Compound 4: middle estimate off by 1.4-fold (0.15 log units), on the high side, and the stated range covers the measured number.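

No step can be read from compound 3 or compound 1 to compound 4, since compound 3 and compound 1 are limits, not numbers: the limit of > 25000 nM in this assay, at which 2 of the 4 values shown sit.

From the compounds shown here alone, the size of the chloro effect on the core of compound 4, and of exchanging piperidin-1-yl for diisopropylamino, remains open.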